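The compounds below may be only part of what the source reports. "The series", "measured", "known", "first", "only" and "open" are said of these compounds alone.

Measured compounds:
compound 1 `Oc1ccc(/C=N/NC(=S)Nc2ccccc2Cl)cc1`, giving 46800 nM in an assay for inhibition of ribonucleoside-diphosphate reductase RR1 (Homo sapiens), with a stated time of 30 min; a higher number here means a weaker inhibitor, a lower number a stronger inhibitor
compound 2 `Cc1ccc(NC(=S)N/N=C/c2ccc(O)cc2)cc1`, giving 14200 nM in this assay

Of the two numbers in hand, compound 1 stands with the higher one; compound 2 sits lower by a margin beyond the scatter. For the measured compounds named here, no step between measured compounds matches the change under consideration, and compound 2 differs from compound 1 in a different way, so its number says nothing direct about the change.

Compound 3 `COc1ccccc1NC(=S)N/N=C/c1ccc(O)cc1` differs from compound 1 by methoxy in place of chloro on an aromatic carbon. Going by the values given here, with no comparable step, the step of a 1.3-fold lower number from compound 1 to compound 3 (0.13 log units; within the scatter) is expected to stay within the scatter, with no firm direction. Compound 3 is therefore estimated at 35000 nM in this assay, with a range from 10000 nM to 120000 nM, the breadth reflecting the absence of any matched precedent.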

Compound 3, half-maximal inhibitory concentration: 41600 nM
The estimate for compound 3 lay 1.2-fold (0.08 log units) below the measured number, and the stated range covers the measured number.
By their numbers in this assay, from the lowest: compound 2; then compounds 3 and 1 (each within the scatter of the next).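

Methoxy in place of chloro on an aromatic carbon ortho to a large group gives a 1.1-fold lower number from compound 1 to compound 3 (0.05 log units; within the scatter) in this assay, the first matched step at this position in the series. Methoxy brings in a hydrogen-bond acceptor and chloro has none, yet the numbers of the two compounds cannot be told apart in this assay, so at this position the assay does not distinguish these two groups. Nothing available bears on why the two groups read alike here.

Open, on these data alone, is whether an amine or a carboxylic acid at the same position would give a number beyond the scatter from that of compound 1. Also open, as far as these compounds go, is whether methoxy and chloro would read alike at other carbons of this six-membered aromatic ring.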